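Swapping chloro for methyl on compound 2

A few compounds are considered here, and "the series" means these few. Any claim that something is new, unique, unknown or untested is made for them only; others in the source may bear on it.

Of the compounds shown here, two have been tested so far in an ADME assay on MT4 cells (Homo sapiens) for cytotoxicity (on this read-out lower numbers stand for higher toxicity in this test and higher numbers for lower toxicity in this test), and only one gave a true number. Compound 1 `CC(=O)n1c(=O)n(Cc2c(F)cccc2F)c2cc(Cl)ccc21` reports > 5950 nM which is a limit of the assay and not a number. Compound 2 `O=c1[nH]c2ccc(Cl)cc2n1S(=O)(=O)c1cc(F)cc(F)c1` gives 202000 nM as the single exact figure, so nothing exact stands beside it for comparison. Compound 3 `Cc1ccc2[nH]c(=O)n(S(=O)(=O)c3cc(F)cc(F)c3)c2c1` differs from compound 2 at one place only: methyl in place of chloro on an aromatic carbon with methyl in place of chloro on an aromatic carbon. Among the measured compounds shown here, no measured pair shows what this exchange does, so the expectation starts from compound 2 at 202000 nM and foresees no shift beyond the usual scatter. The estimated step of a 1.1-fold lower number from compound 2 to compound 3 (0.03 log units; within the scatter) is therefore expected to be small. Compound 3 is expected at 190000 nM with an estimated range of 70000 nM to 400000 nM in this first prediction.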

Compound 3, half-maximal cytotoxic concentration: 23400 nM
Compound 3: middle estimate off by 8.1-fold (0.91 log units), on the high side, outside the stated range (below it).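

In this assay, this place on the aromatic ring of the shared core proves sensitive, as methyl in place of chloro gives an 8.6-fold lower number from compound 2 to compound 3 (0.94 log units; beyond the scatter). A lower number here stands for higher toxicity in this test, so the exchange moves the result towards greater toxicity. Both groups are a single heavy atom, with no hydrogen-bond donors or acceptors and no net charge, so even an exchange this small on paper can move the read-out beyond the usual scatter, though nothing shown here accounts for the size of this step.

This single pair leaves open whether the same exchange would act alike on a different core or with a different group on the sulfonyl. It also leaves open how an amine or a methoxy group at this place would read in this assay.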